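Removing one bromo group from compound 3

The compounds below may be only part of what the source reports. "The series", "measured", "known", "first", "only" and "open" are said of these compounds alone.

Measured in an ADME assay on HEK293 cells (Homo sapiens) for cytotoxicity, read by reporter gene assay and resazurin assay, with a stated time of 48 h; a lower number here means that less compound is tolerated, a higher number that more compound is tolerated:
compound 1 `O=C(Nc1ccccc1)c1cccc(Br)c1`: > 100000 nM (a limit)
compound 2 `O=C(Nc1ccccc1)c1cc(Br)cc(Br)c1`: > 100000 nM (a limit)
compound 3 `O=C(Nc1ccccc1)c1cc(Br)cc(Br)c1O`: 34000 nM

Within the data shown here, compound 3 gives 34000 nM, the only actual number so far. The other two entries are not numbers: they stand at the limit of > 100000 nM in this assay, at which 2 of the 3 values shown sit.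

Compound 4 `O=C(Nc1ccccc1)c1cccc(Br)c1O` comes next. The change hydrogen in place of bromo on an aromatic carbon puts hydrogen in place of bromo on an aromatic carbon, para to a hydroxy group.

Among the measured compounds shown here, two measured steps bear on it. For the measured compounds named here, the one bromo step available, a step that the two limits leave unreadable from compound 1 to compound 2, runs the opposite way, adding a bromo group, and gives no usable size. Going by the values given here, the only readable step, an at least 2.9-fold lower number from compound 2 to compound 3 (0.46 log units; beyond the scatter), came with the hydroxy group entering. Compound 4 keeps that hydroxy group, so a number rather than a limit remains the likelier report in this assay.

The direction is expected to be towards more compound tolerated, though with little support and a modest size. The estimated change is a 1.8-fold higher number from compound 3 to compound 4 (0.25 log units; within the scatter), which may not clear the usual scatter. For compound 4 the expected value is 60000 nM, with an estimated range of 25000 nM to 100000 nM.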

Compound 4, half-maximal cytotoxic concentration: 82000 nM
Estimate against measurement, compound 4: 1.4-fold (0.14 log units) below, within the range that was stated.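

In this assay, among these compounds, hydrogen in place of the bromo group para to the hydroxy group gives the first readable bromo step: a 2.4-fold higher number from compound 3 to compound 4 (0.38 log units; beyond the scatter). With the hydroxy group present, this bromo group therefore makes a difference beyond the scatter, whereas the step from compound 1 to compound 2 cannot be read, as neither compound gives a number, only a limit: the limit of > 100000 nM in this assay, at which 2 of the 4 values shown sit. The hydroxy change also gains a second case, an at least 1.2-fold lower number from compound 1 to compound 4 (0.08 log units; that floor lies within the scatter), but this is only a floor within the scatter, so its size on the core of compound 1 remains unresolved beside an at least 2.9-fold lower number from compound 2 to compound 3 (0.46 log units; beyond the scatter).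

The compounds shown leave open whether the bromo group remaining in compound 4 contributes to the number in this assay in the same way as the one lost from compound 3. They also leave open whether a methoxy group or an amine in place of the hydroxy group would give a number or a limit on this core.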